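One Chlorine Step Carried From One Core to Another

The compounds below may be only part of what the source reports. "The series", "measured", "known", "first", "only" and "open" are said of these compounds alone.

Measured compounds in a functional assay on cells (Cancer cell lines, Homo sapiens) for cytotoxicity, with a stated time of 48 h; on this read-out higher numbers stand for weaker inhibition of growth and lower numbers for stronger inhibition of growth:
Compound 1 `COc1c(/C=C2/C(=O)Nc3ccccc32)c2ccccc2n1-c1ccccc1` gives 3240 nM
Compound 2 `O=C1Nc2ccccc2/C1=C\c1c(Cl)n(CCCc2ccccc2)c2ccccc12` gives 60300 nM
Compound 3 `COc1c(/C=C2/C(=O)Nc3ccc(Cl)cc32)c2ccccc2n1-c1ccccc1` gives 25700 nM

Of the compounds shown here, three have been measured in this assay. Within the data shown here, compound 1 is the one with the lowest number of the three. Compound 3 carries the change chloro in place of hydrogen on an aromatic carbon on the core of compound 1, and this change gave a 7.9-fold higher number from compound 1 to compound 3 (0.90 log units; beyond the scatter). Compound 2 rests on a different core; the difference between the two cores is not broken down here. Among the three measured compounds compound 2 has the highest number, with compound 3 closest to it and compound 1 furthest from it.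

Compound 4 `O=C1Nc2ccc(Cl)cc2/C1=C\c1c(Cl)n(CCCc2ccccc2)c2ccccc12` has not yet been measured. It relates to compound 2 as compound 3 relates to compound 1: the change is chloro in place of hydrogen on an aromatic carbon. The two place descriptions agree word for word, so this is the same change, now made on the core of compound 2 rather than on the core of compound 1.

Among the measured compounds shown here, only one earlier instance of this change is known, and on a different core, so the expectation carries wide uncertainty. Because the step of a 7.9-fold higher number from compound 1 to compound 3 (0.90 log units; beyond the scatter) was beyond the scatter, compound 4 is expected to show a step of about a 5.8-fold higher number from compound 2 to compound 4 (0.76 log units; beyond the scatter) in this assay. Since compound 2 already gives 60300 nM, the expected number for compound 4 is 350000 nM, estimated to fall between 90000 nM and 1200000 nM.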

Compound 4, concentration for total growth inhibition: 5620 nM
Beside the measured number, compound 4's estimate is 62-fold (1.79 log units) above it; measured number below the stated range.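

In this assay the change of chloro in place of hydrogen on an aromatic carbon did not behave on the core of compound 2 as it had on the core of compound 1: it gave an 11-fold lower number from compound 2 to compound 4 (1.03 log units; beyond the scatter), so the added chloro went with stronger inhibition of growth here and with weaker inhibition on the other core. The two instances point in opposite directions, and the gap between them is larger than repeated measurements would explain: the same change on two cores in this assay, a 7.9-fold higher number (0.90 log units; beyond the scatter) from compound 1 to compound 3 and an 11-fold lower number (1.03 log units; beyond the scatter) from compound 2 to compound 4, 85-fold (1.93 log units) apart, beyond the scatter of two such steps. This shows that, for these two pairs, the size and direction of the step depend on the core carrying it, so one instance gave no safe guide to the other; it does not show which part of the cores decides the outcome, since the difference between them is not broken down, and two pairs establish no rule for the series.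

The compounds shown leave open whether a bromo group or an amine on the same aromatic carbon would split between the two cores in the same way. They also leave open which direction the chloro step would take on a third core.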